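The source may report more compounds than this note shows. Statements on the series, on what has been measured and on what is new or still open speak of the compounds shown alone.

Compounds measured so far:
- compound 1, `O=C(c1ccccc1)N1CCC(N(C2CC2)S(=O)(=O)c2cccc(C(F)(F)F)c2)CC1`: 42%
- compound 2, `CS(=O)(=O)c1cccc(S(=O)(=O)N(C2CC2)C2CCN(C(=O)c3cc(F)ccc3S(C)(=O)=O)CC2)c1`: 0%
- compound 3, `CS(=O)(=O)c1ccc(C(=O)N2CCC(N(C3CC3)S(=O)(=O)c3cccc(C(F)(F)F)c3)CC2)cc1`: 52%

In an assay on HEK293 cells for inhibition of Voltage-dependent N-type calcium channel subunit alpha-1B (Homo sapiens), read by FLIPR and calcium flux, tested at 1 uM (on this read-out lower numbers stand for less inhibition and higher numbers for more inhibition at the one concentration tested (going by the name of the read-out)), compound 2 gives the lowest number of the three; compound 1 sits well above it, beyond the scatter, and compound 3 sits further above still. Compound 4, `CS(=O)(=O)c1ccc(F)cc1C(=O)N1CCC(N(C2CC2)S(=O)(=O)c2ccccc2C(F)(F)F)CC1`, has not been measured. It differs from compound 2 in one place: 2-(trifluoromethyl)phenyl in place of 3-(methylsulfonyl)phenyl on a sulfonyl sulfur.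

Within the data shown here, no measured pair shows this exact change. Among the measured compounds shown here, the one step recorded, a number 10 percentage points higher from compound 1 to compound 3 (within the scatter), concerns the benzoyl side of the shared core and lies within the scatter, so it says nothing about the sulfonyl ring. What the numbers do show is that compounds 1 and 3, whose sulfonyl ring carries trifluoromethyl rather than methylsulfonyl, both give sizeable inhibition, while compound 2 gives none. Compound 4 keeps the benzoyl group of compound 2, so the expected step of a number 25 percentage points higher from compound 2 to compound 4 (beyond the scatter) is an upward one of uncertain size. Compound 4 is estimated at 25%, in the range 0% to 55%.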

Compound 4, a percentage reported as inhibition, at one concentration (the size of the read-out at that concentration, not a potency): 17%
Compound 4: the middle estimate sits 8 percentage points above what was measured, and the stated range covers the measured number.
By their numbers in this assay, from the lowest: compound 2; then compound 4; then compounds 1 and 3 (each within the scatter of the next).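

Among these compounds, compound 2 and compound 4 give the first look at the group on the sulfonyl sulfur, since the only earlier step concerned the benzoyl side. In this assay, placing 2-(trifluoromethyl)phenyl there in place of 3-(methylsulfonyl)phenyl gives a number 17 percentage points higher from compound 2 to compound 4 (beyond the scatter). This shows that a change at this position alone can move the read-out beyond the scatter while the benzoyl group stays the same, but no available evidence accounts for the gain.

Because methylsulfonyl leaves as trifluoromethyl enters, these compounds cannot show whether the gain comes from adding one group, removing the other, or the place each occupies on the ring. Going by these compounds, how this position would respond to an amine, a carboxylic acid or a longer chain also remains open.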